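The source may report more compounds than this note shows. Statements on the series, on what has been measured and on what is new or still open speak of the compounds shown alone.

In an ADME assay on BaF3 cells (Mus musculus) for antiproliferative activity, read by CCK-8 assay, with a stated time of 72 h (on this read-out higher numbers stand for weaker inhibition of growth and lower numbers for stronger inhibition of growth), compound 1 `COc1cccc(NC(=O)CCSc2ccc3c(/C=C/c4ccccn4)n[nH]c3c2)c1` gives 3840 nM, compound 2 `O=C(CCSc1ccc2c(/C=C/c3ccccn3)n[nH]c2c1)Nc1cccc(C(F)(F)F)c1` gives 2300 nM and compound 3 `O=C(CCSc1ccc2c(/C=C/c3ccccn3)n[nH]c2c1)Nc1ccc(F)c(C(F)(F)F)c1` gives 610 nM. Compound 3 holds the lowest number of the three, and both of its gaps lie beyond the scatter: a 3.8-fold lower number from compound 2 to compound 3 (0.58 log units; beyond the scatter) and a 6.3-fold lower number from compound 1 to compound 3 (0.80 log units; beyond the scatter). The remaining pair stays within the scatter: a 1.7-fold lower number from compound 1 to compound 2 (0.22 log units; within the scatter).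

Compound 4 `O=C(CCSc1ccc2c(/C=C/c3ccccn3)n[nH]c2c1)Nc1ccc(Cl)c(C(F)(F)F)c1` has chloro in place of fluoro on an aromatic carbon, ortho to a trifluoromethyl group and para to a large group: chloro in place of fluoro on an aromatic carbon.

The nearest evidence is the modest step that placed fluoro on this carbon in place of hydrogen: a 3.8-fold lower number from compound 2 to compound 3 (0.58 log units; beyond the scatter). Going by the values given here, no measured step exchanges one halogen for another, so the size of this change in this assay is not directly known. Compound 4 still carries a halogen there, so most of that gain is expected to remain, with no shift beyond the scatter. The expected change is a 1.2-fold lower number from compound 3 to compound 4 (0.07 log units; within the scatter), a small lean towards stronger inhibition of growth. For compound 4 the estimated value is 520 nM, with an expected range of 210 nM to 1300 nM.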

Compound 4, concentration for 50% growth inhibition: > 10000 nM
Compound 4: a limit, no number; the forecaster's own chance of this, stated with the estimate: 2%; at least 19-fold (1.28 log units) between middle value and limit.
By their numbers in this assay, from the lowest: compound 3; then compounds 2 and 1 (each within the scatter of the next). At a limit, above all of these: compound 4.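

In this assay this carbon, para to a large group, does not accept any halogen equally: an at least 16-fold higher number from compound 3 to compound 4 (1.21 log units; beyond the scatter), a large step from the exchange of one atom. Carrying a halogen here is therefore no guarantee of a gain, as chloro gives an at least 4.3-fold higher number from compound 2 to compound 4 (0.63 log units; beyond the scatter), the opposite direction to fluoro on the same carbon, and the 4-chloro-3-(trifluoromethyl)phenyl group also falls behind 3-methoxyphenyl, with an at least 2.6-fold higher number from compound 1 to compound 4 (0.41 log units; beyond the scatter). The reading for compound 4 is a limit and not a number, so these steps give only minimum sizes: the limit of > 10000 nM in this assay, at which 1 of the 4 values shown sits.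

Going by these compounds, whether bromo, methyl or nitrile on this carbon would fall with fluoro or with chloro remains open. Also open, on these data alone, is whether the fluoro-to-chloro step would repeat with a longer chain in place of the present thioether-amide link.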